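A few compounds are considered here, and "the series" means these few. Any claim that something is new, unique, unknown or untested is made for them only; others in the source may bear on it.

Measured compounds in a toxicity assay on MDCK cells (Canis lupus familiaris) for cytotoxicity, read by crystal violet staining, with a stated time of 48 h; a higher number here means that more compound is tolerated, a lower number that less compound is tolerated:

- Compound 1 `Cc1ccc2cc(C(C)N(Cc3ccc(F)cc3)Cc3ccc(C(C)C)cc3)c(=O)[nH]c2c1` gives > 33000 nM, which is a limit of the assay and not a number.
- Compound 2 `CCCCC(c1cc2ccc(C)cc2[nH]c1=O)N(Cc1ccc(F)cc1)Cc1ccc(C(C)C)cc1` gives > 33000 nM, again a limit.
- Compound 3 `Cc1ccc2cc(CN(Cc3ccc(F)cc3)Cc3ccc(C(C)C)cc3)c(=O)[nH]c2c1` gives > 33000 nM, again a limit.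

Compound 3 therefore stands at the limit, and the two other values shown stand there as well (the limit of > 33000 nM in this assay, at which 3 of the 3 values shown sit). The steps among the measured compounds, from compound 1 to compound 2 a step that the two limits leave unreadable from compound 1 to compound 2, from compound 1 to compound 3 a step that the two limits leave unreadable from compound 1 to compound 3 and from compound 2 to compound 3 a step that the two limits leave unreadable from compound 2 to compound 3, are all left unreadable by the two limits; none of them gives a size.

Compound 4 `Cc1ccc2cc(CN(Cc3ccc(Cl)cc3)Cc3ccc(C(C)C)cc3)c(=O)[nH]c2c1` differs from compound 3 in one place: chloro in place of fluoro on an aromatic carbon. No measured step touches this position, and the steps that are shown concern the saturated chain carbon bound to the amine nitrogen, not the halogen on the aromatic ring. Among the compounds with values here, they bear on the present change only in that every measured compound of the series sits at the limit, and no step has yet revealed a readable effect in this assay.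

For compound 4 the expectation is accordingly a value at or beyond the same limit, estimated at 40000 nM with a range from 20000 nM to 100000 nM. The step from compound 3 to compound 4 is expected to be a step that the limit leaves unreadable from compound 3 to compound 4, that is, no change beyond the scatter, with the value most likely reported again only as a limit.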

Compound 4, half-maximal cytotoxic concentration: > 33000 nM
Compound 4 was reported as a limit (the forecaster's own chance of this, stated with the estimate: 85%); the middle value lies beyond the limit too.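

No step can be read between compound 3 and compound 4 in this assay, since both are reported only as limits, so the exchange of fluoro for chloro has no readable size: the limit of > 33000 nM in this assay, at which 4 of the 4 values shown sit.

The compounds shown leave open how far any of them lies beyond that limit, and whether any change in the series would give a readable value in this assay.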